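Sulfonyl aryl exchange in an EP3 binding series

This account rests on a few compounds, and the source may have more. Where it says the series, first, only, none or still open, it means among the compounds named here.

Measured compounds:
compound 1, `O=C(NS(=O)(=O)c1cc(Cl)c(Cl)s1)OC/C=C1\CCCc2cnn(Cc3ccc(Cl)cc3Cl)c21`, 1 nM
compound 2, `COc1ccc(S(=O)(=O)NC(=O)NC/C=C2\CCCc3cnn(Cc4ccc(Cl)cc4Cl)c32)cc1`, 10 nM

Both numbers come from an assay on isolated protein for displacement of a labelled ligand from prostaglandin E2 receptor EP3 subtype (Homo sapiens), read by scintillation counting, with a stated time of 2 h; a higher number here means a weaker inhibitor, a lower number a stronger inhibitor. Compound 1 gives the lowest of the two; its nearest neighbour, compound 2, stands beyond the usual scatter with a higher number. Among the compounds with values here, compound 2 also differs from compound 1 in more than one place, so no single step between measured compounds is available.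

The next compound is compound 3, `O=C(NS(=O)(=O)c1ccc(Cl)cc1)OC/C=C1\CCCc2cnn(Cc3ccc(Cl)cc3Cl)c21`. It differs from compound 1 in one place: 4-chlorophenyl in place of 4,5-dichlorothiophen-2-yl on a sulfonyl sulfur. Within the data shown here, no measured pair carries this change, so the size of the step rests on the change alone. A small step toward a higher number in this assay is expected, possibly not beyond the scatter. The estimated step of a 3.0-fold higher number from compound 1 to compound 3 (0.48 log units; beyond the scatter) would mean a modest weakening at most. Compound 3 is expected to give 3 nM, within 1 nM to 12 nM.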

Compound 3, inhibition constant: 11 nM
Compound 3: the middle estimate sits 3.7-fold (0.56 log units) below what was measured; the range from low to high includes it.
By their numbers in this assay, from the lowest: compound 1; then compounds 2 and 3 (each within the scatter of the next).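

In this assay, the aryl group on the sulfonyl sulfur proves to be a sensitive point in the series: with the rest of compound 1 unchanged, 4-chlorophenyl in place of 4,5-dichlorothiophen-2-yl gives an 11-fold higher number from compound 1 to compound 3 (1.04 log units; beyond the scatter). Within the data shown here, this is the first step that can be read at a single place, and it comes with no change in heavy-atom count. No measurement available here bears on why the step occurs.

This single exchange changes both the ring and the chlorine count, so the contribution of each remains unresolved; 5-chlorothiophen-2-yl or 3,4-dichlorophenyl on the same sulfonyl sulfur would separate them. On these data alone, it also remains open whether the exchange gives a step of similar size with the linker carried by compound 2.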